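The compounds below may be only part of what the source reports. "The series", "measured", "known", "first", "only" and "open" are said of these compounds alone.

Compound 1 `O=C(O)c1cc2cc(-c3ccc(C(F)(F)F)cc3)ccc2n1O`: > 100000 nM (a limit)
Compound 2 `O=C(O)c1cc2ccc(-c3ccc(Cl)cc3)cc2n1O`: > 100000 nM (a limit)

Both compounds were tested in an ADME assay on HS27 cells (Homo sapiens) for antiproliferative activity, read by sulforhodamine B assay, with a stated time of 48 h; on this read-out higher numbers stand for weaker inhibition and lower numbers for stronger inhibition. Compound 2 gives > 100000 nM, which is a limit of the assay and not a number. Compound 1 gives > 100000 nM, also a limit. The record so far is therefore (the limit of > 100000 nM in this assay, at which 2 of the 2 values shown sit), and compound 2 has a limit rather than a measured potency.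

Compound 3 `O=C(O)c1cc2ccc(-c3ccc(Cl)cc3Cl)cc2n1O` differs from compound 2 in one place: chloro in place of hydrogen on an aromatic carbon. This is chloro in place of hydrogen on an aromatic carbon, ortho to a large group and meta to a chloro group. Going by the values given here, no measured step between two compounds is available as a guide, so the expectation rests on this single small change and on the limit of compound 2.

In this assay, the expected step, a number no higher from compound 2 to compound 3 (the limit leaves the size open), is none beyond the usual scatter, with no direction favoured. A further limit is the most likely report. The estimate for compound 3 is 100000 nM, with an expected range of 30000 nM to 150000 nM.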

Compound 3, half-maximal inhibitory concentration: > 100000 nM
Compound 3 ended at the assay's limit (the forecaster's own chance of this, stated with the estimate: 75%); the middle value sits exactly at the limit.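

Compound 2 and compound 3 both report only a limit, not a number, in this assay, so no step can be read for the added chloro. The compounds shown share one result: the limit of > 100000 nM in this assay, at which 3 of the 3 values shown sit. They leave open whether any compound of this kind gives a measurable potency in this assay, and whether the chloro changes anything.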